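The source may hold more compounds than are shown below. What is called first, only, known or untested is meant among the compounds shown, and "the series" means these compounds.

Among the measured compounds shown here, compound 3 `Oc1cccc(-c2cc(-c3cccc(C(F)(F)F)c3)cc(-c3ccccc3O)n2)c1` gives 13000 nM in a functional assay on DU-145 cells (Homo sapiens) for inhibition (on this read-out lower numbers stand for stronger inhibition and higher numbers for weaker inhibition), the only number. Compound 1 `Oc1ccc(-c2cc(-c3cccc(F)c3)cc(-c3ccccc3O)n2)cc1` sits at the limit, > 50000 nM. Compound 2 `Oc1ccc(-c2cc(-c3ccc(F)cc3)cc(-c3ccccc3O)n2)cc1` likewise sits at the limit, > 50000 nM. For the measured compounds named here, the one measured step, a step that the two limits leave unreadable from compound 1 to compound 2, runs between two limits and concerns a different position, so no measured step covers the change at hand. Compound 4 `Oc1ccc(-c2cc(-c3cccc(C(F)(F)F)c3)cc(-c3ccccc3O)n2)cc1` differs from compound 3 in that (4-hydroxyphenyl in place of 3-hydroxyphenyl on an aromatic carbon). Compound 4 thus carries the 4-hydroxyphenyl that compound 1 and compound 2 share, both resting at the limit (the limit of > 50000 nM in this assay, at which 2 of the 3 values shown sit). A weakening beyond the scatter is therefore expected for compound 4, estimated as a 2.3-fold higher number from compound 3 to compound 4 (0.36 log units; beyond the scatter). Compound 4 is expected at 30000 nM, within 8000 nM to 100000 nM, and may itself return only a limit.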

Compound 4, half-maximal inhibitory concentration: > 50000 nM
Compound 4: only a limit was reported (the forecaster's own chance of this, stated with the estimate: 45%); middle value at least 1.6-fold (0.22 log units) away from the limit.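

Among the compounds shown here, with the 3-(trifluoromethyl)phenyl group held fixed, 4-hydroxyphenyl in place of 3-hydroxyphenyl gives, in this assay, an at least 3.8-fold higher number from compound 3 to compound 4 (0.58 log units; beyond the scatter), the first readable step at this position. The value of compound 4, > 50000 nM, is a limit. The steps joining compound 1 and compound 2 to compound 4 run between limits and cannot be read: the limit of > 50000 nM in this assay, at which 3 of the 4 values shown sit.

On these data alone, whether 3-hydroxyphenyl also gives a number alongside 3-fluorophenyl or 4-fluorophenyl stays open. So does whether a 3-aminophenyl or 3-carboxyphenyl group on this carbon next to the ring nitrogen would hold the level of compound 3.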